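A second chloro on the fused core of compound 4

The source may report more compounds than this note shows. Statements on the series, on what has been measured and on what is new or still open speak of the compounds shown alone.

Compound 1 `Fc1ccc(-c2nn(-c3ccccc3)cc2-c2nc3ccccc3[nH]2)cc1` opens the series. In a functional assay on MCF7 cells (Homo sapiens) for antiproliferative activity, read by MTT assay, with a stated time of 48 h (on this read-out higher numbers stand for weaker inhibition and lower numbers for stronger inhibition), compound 1 gives 3200 nM. Compound 2 `Fc1ccc(-c2nn(-c3ccccc3)cc2-c2nc3cc(Cl)ccc3[nH]2)cc1` differs from compound 1 only by chloro in place of hydrogen on an aromatic carbon, and the step of a 1.4-fold lower number from compound 1 to compound 2 (0.16 log units; within the scatter). Compound 3 `Clc1ccc(-c2nn(-c3ccccc3)cc2-c2nc3cc(Cl)ccc3[nH]2)cc1` carries a further change, where a 1.9-fold lower number from compound 2 to compound 3 (0.28 log units; within the scatter). In this assay compound 3 gives 1170 nM, while compound 2 gives 2230 nM. The numbers for compound 1 and compound 3 lie beyond the usual scatter of each other, but the difference between these two cores is not broken down here.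

Compound 4 `Clc1ccc(-c2nn(-c3ccccc3)cc2-c2nc3cc(Cl)c(Cl)cc3[nH]2)cc1` has not been measured. It differs from compound 3 by chloro in place of hydrogen on an aromatic carbon. This is the same kind of change as that from compound 1 to compound 2, not the same one: in compound 4 the entering chloro sits ortho to a chloro group, whereas in compound 2 no such group stands around the place. Resting on the small step of a 1.4-fold lower number from compound 1 to compound 2 (0.16 log units; within the scatter), compound 4 is expected to give about 950 nM in this assay, a step of a 1.2-fold lower number from compound 3 to compound 4 (0.09 log units; within the scatter). The estimate for compound 4 is expected to fall between 500 nM and 1900 nM.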

Compound 4, half-maximal inhibitory concentration: 48300 nM
Compound 4: middle estimate off by 51-fold (1.71 log units), on the low side; measured number above the stated range.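

In this assay, chloro in place of hydrogen on an aromatic carbon brings a 41-fold higher number from compound 3 to compound 4 (1.62 log units; beyond the scatter), and this large loss of inhibition does not match the earlier step of the same kind: the same change on two cores in this assay, a 1.4-fold lower number (0.16 log units; within the scatter) from compound 1 to compound 2 and a 41-fold higher number (1.62 log units; beyond the scatter) from compound 3 to compound 4, 59-fold (1.77 log units) apart, beyond the scatter of two such steps In this series, then, the change cannot be carried from one core to another as a fixed step, since its size and direction both depend on the core that receives it. The comparison does not show what sets the two steps apart: the entering chloro in compound 4 stands ortho to a chloro group, whereas in compound 2 no such group stands around the place, but the two cores also differ by chloro in place of fluoro, and two steps cannot separate these differences.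

As far as these compounds go, it remains open whether a methyl or methoxy group entering at the same place would also bring so large a step. From the compounds shown here alone, it also remains open whether the second chloro would do so on a core that keeps the fluoro of compound 2.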